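Replacing 4-Methoxyphenyl with (Furan-2-yl)methyl on the Amine

The source may hold more compounds than are shown below. What is called first, only, known or untested is meant among the compounds shown, and "the series" means these compounds.

Measured compounds in a functional assay on L02 cells (Homo sapiens) for inhibition, read by Griess assay, with stated times of 1 h and 24 h; on this read-out higher numbers stand for weaker inhibition and lower numbers for stronger inhibition:
- Compound 1 `COc1cc(/C=C/c2nccc(NC(C)C)n2)cc(OC)c1OC`; compound 1 gives < 40000 nM, which is a limit of the assay rather than a number.
- Compound 2 `CN(c1ccccc1)c1nc(/C=C/c2ccccc2)nc2ccsc12`; compound 2 gives > 1000000 nM, also a limit of the assay and not a number.
- Compound 3 `COc1ccc(Nc2nc(/C=C/c3cc(OC)c(OC)c(OC)c3)nc3ccsc23)cc1`; compound 3 gives 279000 nM.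

Among the measured compounds shown here, compound 3 therefore stands as the only compound with a true number in this assay. The other two values are limits, one at each end of the reported range: the limit of < 40000 nM in this assay, at which 1 of the 3 values shown sits, and (the limit of > 1000000 nM in this assay, at which 1 of the 3 values shown sits). For the measured compounds named here, no two measured compounds differ from each other in a single place, so no step between measured compounds can be read, and nothing about the effect of any single change is known from the numbers themselves.

Compound 4 `COc1cc(/C=C/c2nc(NCc3ccco3)c3sccc3n2)cc(OC)c1OC` has not been measured. It differs from compound 3 in one place:

(furan-2-yl)methyl in place of 4-methoxyphenyl on a nitrogen on an aromatic ring

Everything else in compound 4 is shared with compound 3. Going by the values given here, with no measured step to lean on, the expectation rests on compound 3 alone, whose value is 279000 nM. The change is expected to move the number only modestly, if at all, toward stronger inhibition, so that the expected step is a 1.4-fold lower number from compound 3 to compound 4 (0.14 log units; within the scatter). For compound 4 the estimate in this assay is 200000 nM, with a range from 50000 nM to 800000 nM.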

Compound 4, half-maximal inhibitory concentration: 189000 nM
The estimate for compound 4 lay 1.1-fold (0.02 log units) above the measured number; the range from low to high includes it.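

In this assay, this position now has its first step that can be read: a 1.5-fold lower number from compound 3 to compound 4 (0.17 log units; within the scatter). The earlier compounds shown here offered no such step, and it shows that (furan-2-yl)methyl in place of 4-methoxyphenyl on this nitrogen leaves the two compounds indistinguishable on this read-out, although a six-membered aromatic ring of carbon only gives way to a five-membered aromatic ring with 1 hetero atom, now carried on a methyl link. No measurement shown here gives a cause for this outcome or bears on one.

Going by these compounds, what remains open is whether a different kind of group at this place, such as a longer alkyl chain, a carboxylic acid or a chain ending in an amine, would move the number in this assay beyond the scatter. Steps from compound 3 or compound 4 to compound 1 or compound 2 cannot be read, so the compounds shown also leave open how the parts of the molecule outside this nitrogen substituent affect the number.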